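Returning fluorine, with a methyl, to the amide-side pyridine

The source may report more compounds than this note shows. Statements on the series, on what has been measured and on what is new or still open speak of the compounds shown alone.

Compound 2 `Cc1nc(C(=O)Nc2cccc(C#N)n2)c(C)n1-c1ccc(F)cc1` is the weaker of the two measured compounds in a functional assay on HEK293 cells for negative allosteric modulation of metabotropic glutamate receptor 5 (Homo sapiens), read by FLIPR and calcium flux; a higher number here means a weaker inhibitor, a lower number a stronger inhibitor: compound 2 gives 77 nM, while compound 1 `Cc1nc(C(=O)Nc2cccc(F)n2)c(C)n1-c1ccc(F)cc1` gives 24.2 nM. Among the compounds with values here, the single measured step, a 3.2-fold higher number from compound 1 to compound 2 (0.50 log units; beyond the scatter), put cyano where fluoro had stood on an aromatic carbon. Compound 3 `Cc1nc(NC(=O)c2nc(C)n(-c3ccc(F)cc3)c2C)ccc1F` goes the other way and adds a methyl group; the change from compound 2 is 5-fluoro-6-methylpyridin-2-yl in place of 6-cyanopyridin-2-yl on an amide-type nitrogen. The only step that bears on it is a 3.2-fold higher number from compound 1 to compound 2 (0.50 log units; beyond the scatter); read in reverse, it points to a lower number for compound 3, of similar size, whereas the added methyl has no measured counterpart among these compounds and widens the uncertainty. The expected step is therefore a 3.5-fold lower number from compound 2 to compound 3 (0.54 log units; beyond the scatter) in this assay. Compound 3 is estimated at 22 nM, within a range from 7 nM to 70 nM.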

Compound 3, half-maximal inhibitory concentration: 139 nM
Estimate against measurement, compound 3: 6.3-fold (0.80 log units) below, and the stated range ends below it.
By their numbers in this assay, from the lowest: compound 1; then compounds 2 and 3 (each within the scatter of the next).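

In this assay, a fluorine on the pyridine did not by itself bring back the level of compound 1: 5-fluoro-6-methylpyridin-2-yl in place of 6-fluoropyridin-2-yl gives a 5.7-fold higher number from compound 1 to compound 3 (0.76 log units; beyond the scatter) on the amide-type nitrogen. Against the nitrile-bearing group, the same 5-fluoro-6-methylpyridin-2-yl gives a 1.8-fold higher number from compound 2 to compound 3 (0.26 log units; within the scatter), so these two groups cannot be told apart in this read-out even though their substituents differ. Nothing at hand bears on the reason for either step.

The compounds shown leave open what the methyl does without the fluorine, and what the fluorine does without the methyl, as the two enter together in compound 3. Also open, going by these compounds, is how a chloro or methoxy group on this pyridine would compare.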